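Rearranging an Acetamido-Azole Head Group on a Bradykinin Antagonist

The source may hold more compounds than are shown below. What is called first, only, known or untested is meant among the compounds shown, and "the series" means these compounds.

Compound 1 `CC(=O)Nc1c[nH]nc1NCc1ccc(-c2cc(Cl)cc(F)c2-c2noc(C)n2)cc1F` carries an acetamido-substituted five-membered aromatic ring attached through an amine nitrogen to a saturated chain carbon, which in turn connects to a larger biaryl portion. On these data alone, in a functional assay on IMR-90 cells for antagonist activity at B1 bradykinin receptor (Homo sapiens), read by calcium flux (on this read-out higher numbers stand for weaker inhibition and lower numbers for stronger inhibition), compound 1 stands at "not determined" (no result reported), so its own potency is unknown here. A second, simpler compound 2 `COC(=O)c1c(F)cccc1-c1ccc(CN2CCCC2=O)c(F)c1` shares only part of this framework, and in this assay compound 2 gives 42000 nM, a weak result that says little about compound 1 directly.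

Compound 3 `CC(=O)Nn1ccnc1NCc1ccc(-c2cc(Cl)cc(F)c2-c2noc(C)n2)cc1F` is built from the same atoms as compound 1, joined differently: 1-acetamido-1H-imidazol-2-yl in place of 4-acetamido-1H-pyrazol-3-yl on an amine nitrogen. The change is confined to the acetamido-azole head and its attachment to the amine nitrogen, while the biaryl portion is untouched. Within the data shown here, with no measured step between related compounds, no direction can be read from the data; the expected change in this assay is small, within the scatter, but the starting point is itself unknown. Compound 3 is therefore expected to give about 300 nM, somewhere between 10 nM and 10000 nM.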

Compound 3, half-maximal inhibitory concentration: 1.6 nM
Compound 3: the middle estimate sits 190-fold (2.27 log units) above what was measured, and the stated range ends above it.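

In this assay, among these compounds, compound 3 gives 1.6 nM but compound 1 has no single number to set against it, so no step between compound 1 and compound 3 can be read. The compounds shown leave open how much the rearranged acetamido-azole head changes potency. Nothing here offers an explanation for the result of compound 3.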